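Methoxy for phenyl in a series at the limit

A few compounds are considered here, and "the series" means these few. Any claim that something is new, unique, unknown or untested is made for them only; others in the source may bear on it.

In an ADME assay on Raji cells (Homo sapiens) for cytotoxicity, read by luminescence, with a stated time of 72 h (on this read-out higher numbers stand for an effect only at larger amounts of compound and lower numbers for an effect already at smaller amounts), compound 3 (`CCOC(=O)c1c(-c2cccc(-c3ccccc3)c2)[nH]c2cc(Cl)c(Cl)cc2c1=O`) gives > 21500 nM as a limit and not a number. Compound 1 (`CCOC(=O)c1c(-c2cccc(-c3ccccc3)c2)[nH]c2cc(Cl)ccc2c1=O`) gives > 21500 nM as a limit too. Compound 2 (`CCOC(=O)c1c(-c2cccc(OC)c2)[nH]c2cc(Cl)c(OC)cc2c1=O`) gives > 21500 nM as a limit too.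

The change from compound 3 to compound 4 (`CCOC(=O)c1c(-c2cccc(OC)c2)[nH]c2cc(Cl)c(Cl)cc2c1=O`) is methoxy in place of phenyl on an aromatic carbon, meta to a large group (methoxy in place of phenyl on an aromatic carbon). For the measured compounds named here, the only measured step is a step that the two limits leave unreadable from compound 1 to compound 3 and it concerns chloro in place of hydrogen rather than this change. It offers no size to carry over. The remaining guide is the limit of > 21500 nM in this assay, at which 3 of the 3 values shown sit, and so no step beyond the scatter is expected in this assay, with a report of the same limit as the likeliest outcome. An estimated step that the limit leaves unreadable from compound 3 to compound 4 is expected on that basis. For compound 4 the estimate is 30000 nM with an expected range of 15000 nM to 60000 nM if a number is reported at all.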

Compound 4, half-maximal effective concentration: > 21500 nM
Compound 4 was reported as a limit (the forecaster's own chance of this, stated with the estimate: 90%); the middle value lies beyond the limit too.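

In this assay, for the compounds shown here, compound 4 gives > 21500 nM, a limit and not a number, so no step from compound 2 or compound 3 to compound 4 can be read. The compounds shown leave open whether any of these exchanges alters the half-maximal effective concentration, with no number to compare: the limit of > 21500 nM in this assay, at which 4 of the 4 values shown sit.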